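From a 4-chlorobenzyl to a 3-fluorobenzyl group

The source may hold more compounds than are shown below. What is called first, only, known or untested is meant among the compounds shown, and "the series" means these compounds.

Compounds measured in a functional assay on Bel7402/5-FU cells (Homo sapiens) for antiproliferative activity, read by MTT assay, with a stated time of 72 h (a lower number here means a stronger inhibitor, a higher number a weaker inhibitor), so far
- compound 1 `C=C1C(=O)O[C@H]2[C@H]1CC/C(COC(=O)CCC(=O)OCn1cc(F)c(=O)[nH]c1=O)=C\CC[C@@]1(C)O[C@@H]21` gives > 20000 nM as a limit of the assay, not a number
- compound 2 `C=C1C(=O)O[C@H]2[C@H]1CC/C(COC(=O)CCC(=O)NCCCCCCNC(=O)Cn1cc(F)c(=O)n(Cc3ccccc3)c1=O)=C\CC[C@@]1(C)O[C@@H]21` gives 16200 nM in this test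
- compound 3 `C=C1C(=O)O[C@H]2[C@H]1CC/C(COC(=O)Cn1cc(F)c(=O)n(Cc3ccc(Cl)cc3)c1=O)=C\CC[C@@]1(C)O[C@@H]21` gives 2420 nM in this test

Only two of these results are true numbers. Compound 3 holds the lower of them, and its gap to compound 2 lies beyond the usual scatter, so it is the natural starting point for the next comparison.

Compound 4 `C=C1C(=O)O[C@H]2[C@H]1CC/C(COC(=O)Cn1cc(F)c(=O)n(Cc3cccc(F)c3)c1=O)=C\CC[C@@]1(C)O[C@@H]21` has not yet been measured. It carries 3-fluorophenyl in place of 4-chlorophenyl on a saturated chain carbon bound to an aromatic nitrogen. In other words, 4-chlorobenzyl gives way to 3-fluorobenzyl. Going by the values given here, no two measured compounds differ by a single change, so the data offer no direct guide to this swap. The value of compound 3 at 2420 nM is therefore the anchor for the expectation. The estimated 1.4-fold higher number from compound 3 to compound 4 (0.16 log units; within the scatter) is small, towards a slightly higher number in this assay and within the scatter. Expected for compound 4 is 3500 nM (estimated range 1200 nM to 10000 nM).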

Compound 4, half-maximal inhibitory concentration: 3700 nM
Compound 4: middle estimate off by 1.1-fold (0.02 log units), on the low side, within the range that was stated.
By their numbers in this assay, from the lowest: compounds 3 and 4 (each within the scatter of the next); then compound 2. At a limit, above all of these: compound 1.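

Going by these compounds alone, this is the first pair here that differs in one place only, so it gives the first direct reading of the group on a saturated chain carbon bound to an aromatic nitrogen. In this assay, replacing 4-chlorophenyl with 3-fluorophenyl gives a 1.5-fold higher number from compound 3 to compound 4 (0.18 log units; within the scatter), so the two compounds cannot be told apart, even though the halogen and its place on the phenyl ring change together. Nothing measured here gives a reason for this result.

Going by these compounds, since both features change at once, the effect of each remains unknown, and 3-chlorophenyl or 4-fluorophenyl would be needed to separate them. Also open, on these data alone, is whether a phenyl ring carrying an amine or a carboxylic acid, or a longer chain in place of the benzyl group, would shift the number beyond the scatter.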